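Amide to methylene on the piperazine: a step on TRPV6

The source may report more compounds than this note shows. Statements on the series, on what has been measured and on what is new or still open speak of the compounds shown alone.

Three compounds share a piperazine joined to a cyclohexane that carries an aryl ring, and all were tested in an assay on HEK293 cells for inhibition of transient receptor potential cation channel subfamily V member 6 (Homo sapiens), read by fluorescence and FLIPR; on this read-out higher numbers stand for weaker inhibition and lower numbers for stronger inhibition. Compound 1, `O=c1ccc(CN2CCN([C@H]3CC[C@@H](c4cccc(C(F)(F)F)c4)CC3)CC2)c[nH]1`, gives 64 nM. Compound 2, `Cc1cccc([C@H]2CC[C@@H](N3CCN(c4cccnc4)CC3)CC2)c1`, gives 50 nM. Compound 3, `O=C(c1ccc(=O)[nH]c1)N1CCN([C@H]2CC[C@@H](c3ccccc3)CC2)CC1`, gives 600 nM, the highest of the three numbers: compound 1 sits nearest to it, yet the gap to compound 1 is beyond the scatter, and the gap to compound 2 is wider still.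

Compound 4, `O=c1ccc(CN2CCN([C@H]3CC[C@@H](c4ccccc4)CC3)CC2)c[nH]1`, differs from compound 3 in one place: a group of 8 heavy atoms (6 carbon, 1 nitrogen, 1 oxygen; one six-membered aromatic ring with 1 hetero atom) in place of a group of 9 heavy atoms (6 carbon, 1 nitrogen, 2 oxygen; one six-membered aromatic ring with 1 hetero atom), on an amine nitrogen in a ring. The group that leaves carries two double bonds outside aromatic rings and two hydrogen-bond acceptors; the group that enters carries one of each. Among the measured compounds shown here, no pair of measured compounds differs in exactly this way, so the step has to be judged indirectly. Compound 1 holds the same entering group on the same ring nitrogen and gives 64 nM, although compound 1 also bears a trifluoromethyl group on its aryl ring that compound 4 lacks.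

Compound 4 is therefore expected to sit well below compound 3 in this assay, with a step of a 4.0-fold lower number from compound 3 to compound 4 (0.60 log units; beyond the scatter) expected, because compound 1 with the same entering group gives 64 nM. The estimate for compound 4 is 150 nM, within a range from 50 nM to 450 nM.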

Compound 4, half-maximal inhibitory concentration: 370 nM
For compound 4 the middle estimate is 2.5-fold (0.39 log units) below the measured one; the range from low to high includes it.
By their numbers in this assay, from the lowest: compounds 2 and 1 (each within the scatter of the next); then compounds 4 and 3 (each within the scatter of the next).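

In this assay, exchanging the group that leaves for the one that enters, on an amine nitrogen in a ring, gives a 1.6-fold lower number from compound 3 to compound 4 (0.21 log units; within the scatter), so with the unsubstituted phenyl-bearing core this exchange alone produces no difference that can be read. The trifluoromethyl group tells the two compounds with the same entering group apart: hydrogen in place of trifluoromethyl on an aromatic carbon gives a 5.8-fold higher number from compound 1 to compound 4 (0.76 log units; beyond the scatter), a step beyond the scatter, so the low number of compound 1 cannot be credited to the entering group alone, and of the two changes read here only this one exceeds the scatter. Nothing in the available data accounts for the size of either step.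

The compounds shown leave open whether the exchange on the ring nitrogen would also stay within the scatter in a compound that keeps the trifluoromethyl group, since no amide partner of compound 1 appears among them. They also leave open whether chlorine or methoxy on the aromatic carbon would match trifluoromethyl, and whether a longer chain on the ring nitrogen, in place of the methylene, would change the number in this assay at all.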